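Acetyl in place of methyl on an oxygen: expected effect

A few compounds are considered here, and "the series" means these few. Any claim that something is new, unique, unknown or untested is made for them only; others in the source may bear on it.

Compound 1 `COCc1c(C)coc1-c1ccc2c(c1OC)CCCC2(C)C`: 47.8 uM
Compound 2 `CCOc1c(-c2occ(C)c2CO)ccc2c1CCCC2(C)C`: 39.8 uM
Compound 3 `Cc1coc(-c2ccc3c(c2O)CCC3)c1C(=O)O`: 44.6 uM

All three were tested in a functional assay on MDA-MB-231 cells (Homo sapiens) for cytotoxicity, read by sulforhodamine B assay, with a stated time of 3 days; on this read-out higher numbers stand for an effect only at larger amounts of compound and lower numbers for an effect already at smaller amounts. Compound 1 gives the highest of the three numbers, yet compound 3, the nearest, and compound 2, the furthest, both lie within the scatter of it, so no order can be read among the three.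

Compound 4 `COc1c(-c2occ(C)c2COC(C)=O)ccc2c1CCCC2(C)C` differs from compound 1 by acetyl in place of methyl on an oxygen on a saturated carbon; cut one bond further out, the change reads methoxymethyl to acetoxymethyl. Within the data shown here, no step between measured compounds calibrates a change of this kind, and the three measured values sit close together across the variations present. The step of a 1.1-fold lower number from compound 1 to compound 4 (0.03 log units; within the scatter) is therefore expected to stay within the scatter, in no particular direction. Compound 4 is estimated at 45 uM, with a range of 20 uM to 100 uM.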

Compound 4, concentration for half-maximal effect: 55.6 uM
For compound 4 the middle estimate is 1.2-fold (0.09 log units) below the measured one; the measured number falls inside the stated range.
By their numbers in this assay, from the lowest: compounds 2, 3, 1 and 4 (each within the scatter of the next).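

Acetyl in place of methyl on an oxygen on a saturated carbon gives the first single-place step of the series in this assay (a 1.2-fold higher number from compound 1 to compound 4 (0.07 log units; within the scatter)). At this position, methoxymethyl and acetoxymethyl are therefore not told apart, and the larger group, with its added hydrogen-bond acceptor, leaves the number within the scatter. Nothing at hand offers an explanation for this result. As far as these compounds go, whether an amine in place of that oxygen, or a longer acyl chain such as hexanoyl, would produce a step beyond the scatter remains open.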